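A hydroxy group in place of chloro

The source may hold more compounds than are shown below. What is called first, only, known or untested is meant among the compounds shown, and "the series" means these compounds.

Values measured in a functional assay on MCF7 cells (Homo sapiens); on this read-out higher numbers stand for weaker inhibition of growth and lower numbers for stronger inhibition of growth:

compound 1 `O=S(=O)(/C=C/c1ccc(Cl)c(Cl)c1)Cc1ccc(Nc2ncnc3ccc(Br)cc23)cc1` gives 14000 nM
compound 2 `O=S(=O)(/C=C/c1ccc(Br)cc1)Cc1ccc(Nc2ncnc3ccc(Br)cc23)cc1` gives 5000 nM
compound 3 `O=S(=O)(/C=C/c1ccc(Cl)cc1)Cc1ccc(Nc2ncnc3ccc(Br)cc23)cc1` gives 46000 nM

Compound 3 carries the highest number of the three, and so the weakest inhibition of growth, with compound 1 nearest to it and compound 2 furthest away. Compound 4 `O=S(=O)(/C=C/c1ccc(O)cc1)Cc1ccc(Nc2ncnc3ccc(Br)cc23)cc1` differs from it in one group: hydroxy in place of chloro on an aromatic carbon. Hydroxy stands in place of chloro on an aromatic carbon, para to a large group, so that 4-chlorophenyl becomes 4-hydroxyphenyl.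

Going by the values given here, three measured steps bear on this change. The closest is a 9.2-fold higher number from compound 2 to compound 3 (0.96 log units; beyond the scatter), with chloro in place of bromo on an aromatic carbon. Next come a 3.3-fold higher number from compound 1 to compound 3 (0.52 log units; beyond the scatter) and a 2.8-fold lower number from compound 1 to compound 2 (0.45 log units; beyond the scatter). All three are modest, yet none involves a hydroxy group, so the data give no direct measure of this exchange. Compound 3 at 46000 nM lies at the top of this small range, which makes a lower number the likelier direction, although a higher one cannot be ruled out. The expected change is a 2.3-fold lower number from compound 3 to compound 4 (0.36 log units; beyond the scatter), a modest step in this assay. The estimated value for compound 4 is 20000 nM, with an expected range from 5000 nM to 70000 nM.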

Compound 4, concentration for 50% growth inhibition: 32000 nM
Compound 4: middle estimate off by 1.6-fold (0.20 log units), on the low side, within the range that was stated.
By their numbers in this assay, from the lowest: compound 2; then compound 1; then compounds 4 and 3 (each within the scatter of the next).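

In this assay, putting hydroxy in place of chloro on this aromatic carbon gives a 1.4-fold lower number from compound 3 to compound 4 (0.16 log units; within the scatter) and so does not separate the two groups, even though hydroxy brings a hydrogen-bond donor and a hydrogen-bond acceptor that chloro lacks. Bromo now stands apart from both at this position, since hydroxy in its place gives a 6.4-fold higher number from compound 2 to compound 4 (0.81 log units; beyond the scatter) and chloro in its place gives a 9.2-fold higher number from compound 2 to compound 3 (0.96 log units; beyond the scatter) as well, with both steps beyond the scatter. Going by these compounds alone, the 3,4-dichlorophenyl group also differs from 4-hydroxyphenyl, as the exchange gives a 2.3-fold higher number from compound 1 to compound 4 (0.36 log units; beyond the scatter) and keeps compound 1 apart from the 4-hydroxyphenyl compound in a way that the single hydroxy-for-chloro step does not show.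

No supporting evidence is available to explain why bromo differs from chloro and hydroxy here. On these data alone, it remains open whether a methoxy group, an amine or a carboxylic acid at this position would fall with bromo or with chloro and hydroxy, and whether iodo would extend what bromo shows.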